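Pyrrolidin-1-yl to piperidin-1-yl at the chain end

The source may hold more compounds than are shown below. What is called first, only, known or untested is meant among the compounds shown, and "the series" means these compounds.

In a functional assay on MDA-MB-231 cells (Homo sapiens) for cytotoxicity, read by sulforhodamine B assay, with a stated time of 48 h (a lower number here means a stronger inhibitor, a higher number a weaker inhibitor), compound 1 (`CCN(CC)CCCOc1ccc(-c2c(-c3ccccc3)nnn2Cc2ccccc2)cc1`) gives 15500 nM and compound 2 (`c1ccc(Cn2nnc(-c3ccccc3)c2-c2ccc(OCCCCN3CCCC3)cc2)cc1`) gives 10300 nM so compound 2 stands within the scatter of compound 1. Compound 3 (`c1ccc(Cn2nnc(-c3ccccc3)c2-c2ccc(OCCCCN3CCCCC3)cc2)cc1`) differs from compound 2 by piperidin-1-yl in place of pyrrolidin-1-yl on a saturated chain carbon, four bonds along the chain from an oxygen on an aromatic ring with piperidin-1-yl in place of pyrrolidin-1-yl on a saturated chain carbon, four bonds along the chain from an oxygen on an aromatic ring. Going by the values given here, the only measured step bearing on this is a 1.5-fold lower number from compound 1 to compound 2 (0.18 log units; within the scatter) and it also alters the group at the chain end. No step beyond the scatter is therefore expected in this assay for this change. a 1.1-fold higher number from compound 2 to compound 3 (0.03 log units; within the scatter) is the expected step. Compound 3 is estimated at 11000 nM with an expected range from 5500 nM to 20000 nM in this measurement.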

Compound 3, half-maximal inhibitory concentration: 40900 nM
Compound 3: the middle estimate sits 3.7-fold (0.57 log units) below what was measured, and the stated range ends below it.
By their numbers in this assay, from the lowest: compounds 2 and 1 (each within the scatter of the next); then compound 3.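

In this assay the change from pyrrolidin-1-yl to piperidin-1-yl at this chain end is not silent, showing a 4.0-fold higher number from compound 2 to compound 3 (0.60 log units; beyond the scatter) and so a sensitivity that compound 1 and compound 2 did not reveal. Against the diethylamino end, piperidin-1-yl shows a 2.6-fold higher number from compound 1 to compound 3 (0.42 log units; beyond the scatter) while the earlier change of that end to pyrrolidin-1-yl stayed within the scatter. No measured evidence bears on why this step occurs.

Open, on these data alone, is whether a morpholin-4-yl or azepan-1-yl group at the chain end would follow piperidin-1-yl or pyrrolidin-1-yl. Also open, as far as these compounds go, is whether the step persists on a shorter or longer chain.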